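From (2-hydroxyethyl)amino to pyrrolidin-1-yl on the shared core

This account rests on a few compounds, and the source may have more. Where it says the series, first, only, none or still open, it means among the compounds named here.

Compound 1 `CCNC1CCCc2onc(O)c21`: 278000 nM
Compound 2 `OCCNC1CCCc2onc(O)c21`: > 500000 nM
Compound 3 `Oc1noc2c1C(N1CCCC1)CCC2`: not yet measured

In a functional assay with Mus musculus as the target (on this read-out lower numbers stand for stronger inhibition and higher numbers for weaker inhibition), compound 1 gives 278000 nM. Compound 2 has no exact number, and its > 500000 nM is a limit of this assay. Compound 3 differs from compound 2 by pyrrolidin-1-yl in place of (2-hydroxyethyl)amino on a saturated ring carbon. Within the data shown here, the only measured step, an at least 1.7-fold higher number from compound 1 to compound 2 (0.25 log units; that floor lies within the scatter), bears on this change only loosely, since it adds a hydroxy to a saturated chain carbon and introduces no ring. Among the measured compounds shown here, no large step is therefore expected in this assay, and compound 3 should stay weak. The expected step is an at least 1.2-fold lower number from compound 2 to compound 3 (0.09 log units; that floor lies within the scatter). Compound 3 is estimated at 400000 nM, with an expected range of 130000 nM to 1200000 nM.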

Compound 3, half-maximal inhibitory concentration: > 500000 nM
Compound 3: only a limit was reported; the forecaster's own chance of this, stated with the estimate: 50%; at least 1.2-fold (0.09 log units) between middle value and limit.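

In this assay compound 3 gives > 500000 nM, which is a limit of the assay and not a number. So pyrrolidin-1-yl, the first group here with a ring on this saturated ring carbon, also yields no exact number, and in place of ethylamino it gives an at least 1.7-fold higher number from compound 1 to compound 3 (0.25 log units; that floor lies within the scatter). The steps between compound 2 and compound 3 cannot be read, as both rest on the same limit: the limit of > 500000 nM in this assay, at which 2 of the 3 values shown sit.

Going by these compounds, whether a primary amine or a longer chain such as butylamino at this carbon would give a measurable value remains open.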